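Swapping methoxy for nitro on the shared core

The source may report more compounds than this note shows. Statements on the series, on what has been measured and on what is new or still open speak of the compounds shown alone.

Compound 3 `COc1ccc(C(=O)/C=C/c2ccc(OCc3cn(Cc4ccc(F)cc4)nn3)cc2)cc1` gives the lowest number of the three compounds measured in a functional assay on MCF7 cells (Homo sapiens) for inhibition, read by MTT assay, with a stated time of 48 h, tested at 10 uM (on this read-out higher numbers stand for more inhibition of growth at the one concentration tested and lower numbers for less inhibition of growth), at 15%. Compound 1 `COc1ccc(C(=O)/C=C/c2ccc(OCc3cn(Cc4ccccc4F)nn3)cc2)cc1` gives 32%, and compound 2 `COc1ccc(C(=O)/C=C/c2ccc(OCc3cn(Cc4cccc(F)c4)nn3)cc2)cc1` gives 41%. The measured steps of a number 9 percentage points higher from compound 1 to compound 2 (within the scatter), a number 17 percentage points lower from compound 1 to compound 3 (beyond the scatter) and a number 26 percentage points lower from compound 2 to compound 3 (beyond the scatter) all concern where the fluorine sits on the fluorophenyl group. Compound 4 `O=C(/C=C/c1ccc(OCc2cn(Cc3ccc(F)cc3)nn2)cc1)c1ccc([N+](=O)[O-])cc1` differs from compound 3 in a different part of the molecule: nitro in place of methoxy on an aromatic carbon. Among the compounds with values here, none of the measured steps touches this part, so they give no guide to the size or direction of the change in this assay. The expected step is a number 5 percentage points higher from compound 3 to compound 4 (within the scatter), which cannot be separated from the scatter. Compound 4 is estimated at 20%, between 0% and 45%.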

Compound 4, percent growth inhibition at one concentration: 38%
The estimate for compound 4 lay 18 percentage points below the measured number; low and high end bracket the measured number.
By their numbers in this assay, from the lowest: compound 3; then compounds 1, 4 and 2 (each within the scatter of the next).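

Until now only the fluorine had moved, but in this assay nitro in place of methoxy gives a number 23 percentage points higher from compound 3 to compound 4 (beyond the scatter), so the far end of the molecule also affects growth inhibition. This aromatic carbon, para to a large group, is therefore not indifferent to what it carries, at least with the 4-fluorophenyl group in place. Nothing available explains the rise.

From the compounds shown here alone, whether nitro has the same effect alongside the 2-fluorophenyl or 3-fluorophenyl group stays open. So does the outcome with an amine or a carboxylic acid at this position.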